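Lengthening the ester chain of compound 1

A few compounds are considered here, and "the series" means these few. Any claim that something is new, unique, unknown or untested is made for them only; others in the source may bear on it.

Compound 1 `COC(=O)c1cc(N2C(=O)C3=C(CCCC3)C2=O)ccc1Cl` gives 1780 nM
Compound 2 `COC(=O)c1cc(N2C(=O)C3=C(CCCC3)C2=O)c(F)cc1Cl` gives 67.6 nM
Compound 3 `CCCOC(=O)c1cc(N2C(=O)C3=C(CCCC3)C2=O)c(F)cc1Cl` gives 33.1 nM

In a functional assay on the whole organism for inhibition, with Scenedesmus acutus as the target (on this read-out lower numbers stand for stronger inhibition and higher numbers for weaker inhibition), compound 1 has the highest of the three numbers. Compound 4 `CC(C)COC(=O)c1cc(N2C(=O)C3=C(CCCC3)C2=O)ccc1Cl` differs from it by isopropyl in place of hydrogen on a saturated chain carbon bound to an oxygen next to a carbonyl group in one place: isopropyl in place of hydrogen on a saturated chain carbon bound to an oxygen next to a carbonyl group. Methoxycarbonyl thus becomes isobutoxycarbonyl. The closest measured change is a 2.0-fold lower number from compound 2 to compound 3 (0.31 log units; beyond the scatter) for ethyl on that kind of carbon, though both of those compounds carry fluoro. The other step, a 26-fold lower number from compound 1 to compound 2 (1.42 log units; beyond the scatter) for fluoro on an aromatic carbon, is not part of this change. The expected step in this assay is a 2.1-fold lower number from compound 1 to compound 4 (0.32 log units; beyond the scatter) and so modest. Compound 4 is expected at 850 nM (estimated range 300 nM to 2000 nM).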

Compound 4, half-maximal inhibitory concentration: 977 nM
For compound 4 the middle estimate is 1.1-fold (0.06 log units) below the measured one, and the stated range covers the measured number.
By their numbers in this assay, from the lowest: compound 3; then compound 2; then compounds 4 and 1 (each within the scatter of the next).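

In this assay isobutoxycarbonyl in place of methoxycarbonyl gives a 1.8-fold lower number from compound 1 to compound 4 (0.26 log units; within the scatter), so on the core without fluoro this change cannot be told apart from the ordinary spread of repeat measurements. The earlier ester step, a 2.0-fold lower number from compound 2 to compound 3 (0.31 log units; beyond the scatter), was read with ethyl on compounds carrying fluoro, so it sets no general rule for this position.

From the compounds shown here alone, whether isobutoxycarbonyl would do more on the core of compound 2, and what a carboxylic acid or a longer chain would do here, stays open. Nothing measured here gives a reason for these results.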